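Moving the chlorine on the aryl ketone ring of compound 2

The source may hold more compounds than are shown below. What is called first, only, known or untested is meant among the compounds shown, and "the series" means these compounds.

Compound 2, with the structure `N=C(N)N/N=C/c1ccc(/C=C/C(=O)c2cccc(Cl)c2)cc1`, gives 80.7% in a functional assay on the whole organism (Ear) for inhibition, with Mus musculus as the target, with a stated time of 30 min, at a dose of 100 mg/kg by the intraperitoneal route; on this read-out higher numbers stand for more inhibition at the one dose given (going by the name of the read-out) and lower numbers for less inhibition. Among the three compounds measured, its number sits close to that of compound 3, `O=C(N/N=C/c1ccc(/C=C/C(=O)c2ccc(Cl)cc2Cl)cc1)c1ccncc1`, which gives 83.8%, a gap that lies within the scatter; compound 1, `O=C(N/N=C/c1ccc(/C=C/C(=O)c2ccccc2F)cc1)c1ccncc1`, gives 51.3%, clearly lower than compound 2 by a gap beyond the scatter. Compound 4, `N=C(N)N/N=C/c1ccc(/C=C/C(=O)c2ccccc2Cl)cc1`, has not been measured. It differs from compound 2 by 2-chlorophenyl in place of 3-chlorophenyl on a carbonyl carbon. Among the compounds with values here, the only measured step that touches the aryl ring on the carbonyl carbon is a number 32.5 percentage points higher from compound 1 to compound 3 (beyond the scatter), but that step also changes the halogen and adds a second one, so it does not tell how the chlorine's place alone matters. Within the data shown here, with no measured step that moves a single chlorine on that ring, the expected step of a number 9.7 percentage points lower from compound 2 to compound 4 (within the scatter) is modest and uncertain in direction, most likely within the scatter. Compound 4 is therefore estimated to give 71%, in a range from 52% to 87%.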

Compound 4, a percentage reported as inhibition, in the whole organism at one dose (the size of the read-out at that dose, not a potency): 84.1%
For compound 4 the middle estimate is 13.1 percentage points below the measured one; the range from low to high includes it.
By their numbers in this assay, from the lowest: compound 1; then compounds 2, 3 and 4 (each within the scatter of the next).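

Having 2-chlorophenyl in place of 3-chlorophenyl on a carbonyl carbon gives a number 3.4 percentage points higher from compound 2 to compound 4 (within the scatter) in this assay. Within the data shown here, this is the first measured step that changes only the place of the chlorine, with no change of halogen and no second halogen added. At this one dose, the two places of the chlorine therefore cannot be told apart, and no measurement on hand bears on why the two numbers stand so close.

As far as these compounds go, it remains open whether the chlorine itself matters, that is, how a plain phenyl, or an amine or a carboxylic acid in place of the chlorine, would read on this ring. A single dose also leaves open whether compound 2 and compound 4 would stay this close at lower doses.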